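The compounds below may be only part of what the source reports. "The series", "measured", "known", "first", "only" and "open" are said of these compounds alone.

In a functional assay on HepG2 cells (Homo sapiens) for inhibition, read by MTT assay, with a stated time of 48 h (a higher number here means a weaker inhibitor, a lower number a stronger inhibitor), compound 1 `COc1ccc(N(C)c2nc(C)nc3ccccc23)cc1[Se]C` gives 17 nM and compound 2 `COc1ccc(N(C)c2nc(C)nc3ccccc23)cc1OCC[Se]C#N` gives 14 nM, two numbers within the scatter of each other. Compound 3 `COc1ccc(N(C)c2nc(C)nc3ccccc23)cc1OCCN` departs from compound 2 by one nitrogen atom in place of a group of 3 heavy atoms (1 carbon, 1 nitrogen, 1 selenium; no ring), on a saturated chain carbon, two bonds along the chain from an oxygen on an aromatic ring. For the measured compounds named here, the only measured step, a 1.2-fold lower number from compound 1 to compound 2 (0.08 log units; within the scatter), changes a larger part of the molecule yet stays within the scatter. Going by the values given here, it bears only loosely on this change, since no measured compound carries the amino group. A modest weakening is therefore expected, held with caution. The estimated step is a 2.5-fold higher number from compound 2 to compound 3 (0.40 log units; beyond the scatter). For compound 3 the expected value is 35 nM, within an estimated range of 10 nM to 150 nM.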

Compound 3, half-maximal inhibitory concentration: 343 nM
Beside the measured number, compound 3's estimate is 9.8-fold (0.99 log units) below it; the measured number lies above the stated range.
By their numbers in this assay, from the lowest: compounds 2 and 1 (each within the scatter of the next); then compound 3.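

In this assay, the end of this chain proves sensitive to change: a 25-fold higher number from compound 2 to compound 3 (1.39 log units; beyond the scatter) with amino in place of the selenium-bearing group. The selenium-free compound 3 also separates from the other selenium compound, a 20-fold higher number from compound 1 to compound 3 (1.30 log units; beyond the scatter), whereas the two selenium compounds stay within the scatter of each other. No measurement at hand explains this loss. The compounds shown leave open whether the amino group itself or the absence of selenium accounts for it. A hydroxyl group at the chain end, or a longer chain carrying the amino group, would bear on that question.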